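Replacing the aryl on the ring nitrogen of compound 3

The compounds below may be only part of what the source reports. "The series", "measured", "known", "first", "only" and "open" are said of these compounds alone.

Three compounds have been measured in a functional assay on HT-29 cells (Homo sapiens) for antiproliferative activity, read by MTT assay, with a stated time of 72 h; on this read-out higher numbers stand for weaker inhibition and lower numbers for stronger inhibition:
- compound 1 `O=C(Nc1ccc(Oc2ccnc3[nH]ccc23)c(F)c1)c1cc2cccnc2n(-c2ccc(C(F)(F)F)cc2Cl)c1=O` gives 1360 nM
- compound 2 `Cn1ccc2c(Oc3ccc(NC(=O)c4cc5cccnc5n(-c5ccccc5)c4=O)cc3F)ccnc21` gives 510 nM
- compound 3 `Cn1ccc2c(Oc3ccc(NC(=O)c4cc5cccnc5n(-c5ccc(Br)cc5)c4=O)cc3F)ccnc21` gives 330 nM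

Compound 3 holds the lowest number of the three, but compound 2 sits within the scatter of it, so the two cannot be told apart; only compound 1 stands clearly apart, with a higher number beyond the scatter. Compound 4 `Cn1ccc2c(Oc3ccc(NC(=O)c4cc5cccnc5n(-c5ccc(C(F)(F)F)cc5Cl)c4=O)cc3F)ccnc21` is not yet measured. It differs from compound 3 in one place: 2-chloro-4-(trifluoromethyl)phenyl in place of 4-bromophenyl on an aromatic nitrogen.

Among the compounds with values here, only one measured step bears on this change, a 1.5-fold lower number from compound 2 to compound 3 (0.19 log units; within the scatter), which altered the same aryl group and stayed within the scatter. Within the data shown here, no measured pair isolates the switch to the 2-chloro-4-(trifluoromethyl)phenyl group itself. Compound 1 carries that same group on an otherwise related core and gives 1360 nM, a higher number than compound 3, though compound 1 differs from compound 4 in another place too, so its value is only a loose pointer. The expected step is therefore a modest rise in the number, a 1.7-fold higher number from compound 3 to compound 4 (0.22 log units; within the scatter), with wide uncertainty. For compound 4 the estimated value in this assay is 550 nM, between 200 nM and 1500 nM.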

Compound 4, half-maximal inhibitory concentration: 5830 nM
For compound 4 the middle estimate is 11-fold (1.03 log units) below the measured one, and the stated range ends below it.
By their numbers in this assay, from the lowest: compounds 3 and 2 (each within the scatter of the next); then compound 1; then compound 4.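

In this assay, the aryl group on the ring nitrogen proves sensitive to some changes but not others: a 1.5-fold lower number from compound 2 to compound 3 (0.19 log units; within the scatter) gave no clear difference, whereas 2-chloro-4-(trifluoromethyl)phenyl gives an 18-fold higher number from compound 3 to compound 4 (1.25 log units; beyond the scatter) and an 11-fold higher number from compound 2 to compound 4 (1.06 log units; beyond the scatter). With that aryl group in place, the aromatic nitrogen of the other ring system also matters, since methyl in place of hydrogen gives a 4.3-fold higher number from compound 1 to compound 4 (0.63 log units; beyond the scatter). Compound 2 and compound 3 carry that methyl as well and still have much lower numbers than compound 4, so the methyl alone does not account for the high number of compound 4. Nothing measured here explains why these steps are so large.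

From the compounds shown here alone, the chloro and the trifluoromethyl enter together, so it remains open whether one of them accounts for most of the rise or whether the two are needed together. Going by these compounds, how a pyridyl ring or a plain alkyl chain on the ring nitrogen would read also remains open.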